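One group exchanged between compound 3 and compound 4

The source may hold more compounds than are shown below. What is called first, only, known or untested is meant among the compounds shown, and "the series" means these compounds.

Measured in a functional assay on HEK-293T cells (Homo sapiens) for cytotoxicity, read by MTT assay (a higher number here means that more compound is tolerated, a lower number that less compound is tolerated), so far
- Compound 1 `COc1ccc(-c2nc3cnccn3c2Nc2cc(OC)c(OC)c(OC)c2)cc1O` gives 38000 nM
- Compound 2 `COc1cc(Nc2c(-c3ccc(F)cc3)nc3cnccn23)cc(OC)c1OC` gives 36000 nM
- Compound 3 `COc1ccc(Nc2c(-c3ccc(F)cc3)nc3cnccn23)cc1` gives 56000 nM

In this assay compound 3 lies within the scatter of both compound 1 and compound 2. Compound 4 `COc1ccc(Nc2c(-c3ccc(OC)c(O)c3)nc3cnccn23)cc1` carries 3-hydroxy-4-methoxyphenyl in place of 4-fluorophenyl on an aromatic carbon and is otherwise the same as compound 3. Within the data shown here, the only measured step that bears on this is the same exchange in the opposite direction, a 1.1-fold lower number from compound 1 to compound 2 (0.02 log units; within the scatter) and it was measured on a different background, so it guides only loosely. No change beyond the scatter is therefore expected, and the expected step is a 1.0-fold higher number from compound 3 to compound 4 (0.02 log units; within the scatter) at most a small one. The estimate for compound 4 is 58000 nM with an expected range from 30000 nM to 110000 nM at the upper end.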

Compound 4, concentration lethal to 50% of the cells: 38000 nM
Compound 4: the middle estimate sits 1.5-fold (0.18 log units) above what was measured, within the range that was stated.
By their numbers in this assay, from the lowest: compounds 2, 1, 4 and 3 (each within the scatter of the next).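

In this assay putting 3-hydroxy-4-methoxyphenyl in place of 4-fluorophenyl on this aromatic carbon brings a 1.5-fold lower number from compound 3 to compound 4 (0.17 log units; within the scatter) and so gives the change a second reading on another core. On neither core does the change move the number beyond the scatter, and the two readings agree with each other: the same change on two cores in this assay, a 1.1-fold lower number (0.02 log units; within the scatter) from compound 1 to compound 2 and a 1.5-fold higher number (0.17 log units; within the scatter) from compound 4 to compound 3, 1.6-fold (0.19 log units) apart, within the scatter of two such steps

Going by these compounds, whether a group of a different kind on this carbon, such as an amine or a carboxylic acid, would move the number beyond the scatter in this assay stays open.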